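A few compounds are considered here, and "the series" means these few. Any claim that something is new, unique, unknown or untested is made for them only; others in the source may bear on it.

In a functional assay on RKO cells (Homo sapiens) for inhibition, read by MTT assay, with a stated time of 48 h (a higher number here means a weaker inhibitor, a lower number a stronger inhibitor), compound 2 (`COc1ccc(N(C)c2nc(C)nc3ccccc23)cc1C(=O)NCC[Se]C#N`) gives 1170 nM and compound 1 (`COc1ccc(N(C)c2nc(C)nc3ccccc23)cc1C(=O)OCCC[Se]C#N`) gives 1140 nM, two numbers within the scatter of each other and together far above compound 3 (`Cc1nc(N(C)c2ccc([Se]C#N)c(Cl)c2)c2ccccc2n1`), which gives 11 nM. The change from compound 2 to compound 4 (`COc1ccc(N(C)c2nc(C)nc3ccccc23)cc1OCCCC[Se]C#N`) is a group of 8 heavy atoms (5 carbon, 1 nitrogen, 1 oxygen, 1 selenium; no ring) in place of a group of 8 heavy atoms (4 carbon, 2 nitrogen, 1 oxygen, 1 selenium; no ring), on an aromatic carbon and it stands ortho to a methoxy group. Going by the values given here, the only measured step that bears on it is a 1.0-fold higher number from compound 1 to compound 2 (0.01 log units; within the scatter), a swap on a carbonyl carbon that stayed within the scatter. In this assay no step beyond the scatter is therefore expected, and the estimated step is a 1.2-fold lower number from compound 2 to compound 4 (0.07 log units; within the scatter) as a rough guide. For compound 4 the expected value is 1000 nM, with an estimated range from 350 nM to 3000 nM here.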

Compound 4, half-maximal inhibitory concentration: 1360 nM
For compound 4 the middle estimate is 1.4-fold (0.13 log units) below the measured one, and the stated range covers the measured number.
By their numbers in this assay, from the lowest: compound 3; then compounds 1, 2 and 4 (each within the scatter of the next).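

In this assay, the exchange at this aromatic carbon, ortho to a methoxy group, gives a 1.2-fold higher number from compound 2 to compound 4 (0.07 log units; within the scatter), although the entering group has no double bond and 0 hydrogen-bond donors. The exchange against the other carbonyl-bearing group gives a 1.2-fold higher number from compound 1 to compound 4 (0.08 log units; within the scatter), so at this carbon the carbonyl can be absent without a step beyond the scatter. No measurement shown explains this lack of change. Still open, going by these compounds, is how a longer chain at this carbon, or an amine linking the chain to the ring, would read in this assay.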